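Intrinsic activity with a propyl chain on the core nitrogen

The source may report more compounds than this note shows. Statements on the series, on what has been measured and on what is new or still open speak of the compounds shown alone.

Compound 1 `CN1CCN(CCNC(=O)n2c(=O)n(Cc3ccccc3)c3ccccc32)CC1` carries a benzyl group on one ring nitrogen of the shared core. In a functional assay for agonist activity at 5-hydroxytryptamine receptor 4 (Cavia porcellus) (a higher number here means a larger maximal response, a lower number a smaller maximal response), compound 1 reaches only a limit of the assay, < 0.3, not a number. Compound 2 `C=CCn1c(=O)n(C(=O)NCCN2CCN(C)CC2)c2ccccc21` differs from it by vinyl in place of phenyl on a saturated chain carbon bound to an aromatic nitrogen, and in this assay compound 2 gives 0.63. Going by the values given here, compound 3 `CC(C)n1c(=O)n(C(=O)NCCN2CCN(C)CC2)c2cc(Cl)ccc21` is the only other compound with a number, and in this assay compound 3 gives 0.7, which lies within the usual scatter of compound 2. Among the compounds with values here, the single step measured at this position, a number at least 0.33 higher from compound 1 to compound 2 (beyond the scatter), is large, and the limit of < 0.3 in this assay, at which 1 of the 3 values shown sits, marks its starting point.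

Compound 4 `CCCCn1c(=O)n(C(=O)NCCN2CCN(C)CC2)c2ccccc21` is the unmeasured compound. propyl in place of vinyl on a saturated chain carbon bound to an aromatic nitrogen The step from phenyl to vinyl bears on it, since it sits at the same place, but propyl in place of vinyl is a much smaller change between two short chains. For that reason the step expected a number 0.020 higher from compound 2 to compound 4 (within the scatter) is small and probably within the scatter. Compound 4 is expected to give 0.65 in this assay, with a likely range from 0.45 to 0.85.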

Compound 4, intrinsic activity: the largest response reached, as a fraction of the reference agonist's: < 0.3
Compound 4: no number, only a limit; the forecaster's own chance of this, stated with the estimate: 10%; middle value at least 0.35 from the limit.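

The earlier compounds shown here showed a large effect only when a benzyl group gave way to a short open chain, and that result could suggest that any such chain is tolerated here. In this assay, going from allyl to butyl on a saturated chain carbon bound to an aromatic nitrogen gives a number at least 0.33 lower from compound 2 to compound 4 (beyond the scatter), so the maximal response depends strongly on which short chain sits at this place, and two chains of similar kind can behave very differently. The step from compound 1 to compound 4 cannot be read, since both values are limits and not numbers, but a group with a ring and a group without one now share the same low end: the limit of < 0.3 in this assay, at which 2 of the 4 values shown sit.

This change removes a double bond outside aromatic rings and adds a carbon at the same time, and the compounds shown cannot separate those two differences. Also open, from the compounds shown here alone, is what an ethyl group, a longer chain or a chain ending in an amine would give at this place, and so whether the high response belongs to allyl alone.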